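Carrying a Dimethoxy Anilino Swap Onto a Second Core

The compounds below may be only part of what the source reports. "The series", "measured", "known", "first", "only" and "open" are said of these compounds alone.

Compound 1 `COc1ccc(Nc2nc3ccccc3nc2S(=O)(=O)c2ccccc2)cc1` gives 640 nM in a functional assay on HL-60 cells (Homo sapiens) for cytotoxicity, read by MTT assay, with a stated time of 72 h; a higher number here means a weaker inhibitor, a lower number a stronger inhibitor. Compound 2 `COc1cc(Nc2nc3ccccc3nc2S(=O)(=O)c2ccccc2)cc(OC)c1` carries 3,5-dimethoxyphenyl in place of 4-methoxyphenyl on a nitrogen on an aromatic ring and in this assay compound 2 gives 50 nM, a step of a 13-fold lower number from compound 1 to compound 2 (1.11 log units; beyond the scatter). Compound 3 `COc1ccc(Nc2nc3ccccc3nc2S(=O)(=O)c2ccc(OC)cc2)cc1` differs from compound 1 by methoxy in place of hydrogen on an aromatic carbon; in this assay compound 3 gives 1190 nM, and the step is a 1.9-fold higher number from compound 1 to compound 3 (0.27 log units; within the scatter). Compound 4 `COc1ccc(S(=O)(=O)c2nc3ccccc3nc2Nc2cc(OC)cc(OC)c2)cc1` has not been measured. It relates to compound 3 as compound 2 relates to compound 1: 3,5-dimethoxyphenyl in place of 4-methoxyphenyl on a nitrogen on an aromatic ring, the same change at the same kind of place, on a core that differs only by methoxy in place of hydrogen on an aromatic carbon. The expected step rests on the earlier one, a 13-fold lower number from compound 1 to compound 2 (1.11 log units; beyond the scatter), and is estimated at a 13-fold lower number from compound 3 to compound 4 (1.10 log units; beyond the scatter). Among the measured compounds shown here, compound 4 is therefore expected to give about 95 nM, the range reflecting that only one earlier example of this change exists.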

Compound 4, half-maximal inhibitory concentration: 1710 nM
Compound 4: middle estimate off by 18-fold (1.26 log units), on the low side, outside the stated range (above it).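

In this assay, 3,5-dimethoxyphenyl in place of 4-methoxyphenyl gave a 1.4-fold higher number from compound 3 to compound 4 (0.16 log units; within the scatter), so the large drop seen on the core of compound 1 did not carry over to the methoxy-bearing core: the same change on two cores in this assay, a 13-fold lower number (1.11 log units; beyond the scatter) from compound 1 to compound 2 and a 1.4-fold higher number (0.16 log units; within the scatter) from compound 3 to compound 4, 18-fold (1.26 log units) apart, beyond the scatter of two such steps. Read the other way, methoxy in place of hydrogen on an aromatic carbon gave a 34-fold higher number from compound 2 to compound 4 (1.53 log units; beyond the scatter), and this change too depended on its partner: the same change on two cores in this assay, a 1.9-fold higher number (0.27 log units; within the scatter) from compound 1 to compound 3 and a 34-fold higher number (1.53 log units; beyond the scatter) from compound 2 to compound 4, 18-fold (1.26 log units) apart, beyond the scatter of two such steps. Among the compounds shown here, the two changes therefore did not add independently in these four compounds, but this does not show why, and each core offers only one example of the swap.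

From the compounds shown here alone, it remains open whether a chlorine, a methyl group or a dimethylamino group at that aromatic carbon would also cancel the step.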